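The source may hold more compounds than are shown below. What is called first, only, known or untested is meant among the compounds shown, and "the series" means these compounds.

Working notes on the series, read in an ADME assay on cells (Homo sapiens) for cytotoxicity, read by resazurin assay, with a stated time of 5 days; on this read-out higher numbers stand for lower toxicity in this test and lower numbers for higher toxicity in this test. Compound 1 `COc1ccc(-c2nc(/C=C\c3cccc(Cl)c3)nc3ccsc23)cn1` gives 53000 nM. Compound 2 `c1ccc(-c2cc(CNc3nncc(-c4cccc5ccccc45)n3)n[nH]2)cc1` reads > 10000 nM, which is a limit of the assay and not a number. Going by the values given here, compound 3 `COc1ccc(Nc2nc(CS(=O)(=O)c3cccc(Cl)c3)nc3ccsc23)cc1` gives 60000 nM, which lies within the scatter of the value for compound 1, so the two stand level and are the only true numbers to hand in this assay.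

The next step leads from compound 3 to compound 4 `O=S(=O)(Cc1nc(-c2ccncc2)c2sccc2n1)c1cccc(Cl)c1`, with the change pyridin-4-yl in place of (4-methoxyphenyl)amino on an aromatic carbon of the shared core. Among the compounds with values here, no pair of measured compounds differs in one place only, so the size of this change has no direct precedent. The expectation rests only on the level shown by compound 1 at 53000 nM and compound 3 at 60000 nM. On that basis, no shift beyond the scatter is expected, and the estimated step is a 1.2-fold lower number from compound 3 to compound 4 (0.08 log units; within the scatter). With so little to go on, the range is kept wide and a reading reported only as a limit stays possible. The estimated value for compound 4 is 50000 nM, with an expected range of 20000 nM to 100000 nM.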

Compound 4, half-maximal cytotoxic concentration: > 50000 nM
Compound 4: only a limit was reported; the forecaster's own chance of this, stated with the estimate: 20%; the middle value sits exactly at the limit.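

Compound 4 reads > 50000 nM, which is a limit of the assay and not a number. Going by these compounds alone, the step from compound 3 to compound 4 therefore cannot be read, and this result yields no new step. The compounds shown leave open how far pyridin-4-yl in place of (4-methoxyphenyl)amino on an aromatic carbon shifts the read-out in this assay.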